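Swapping the Ring on the Thiocarbonyl Carbon

The source may report more compounds than this note shows. Statements on the series, on what has been measured and on what is new or still open speak of the compounds shown alone.

Of the compounds shown here, two have been measured in a functional assay on A-375 cells (Homo sapiens) for cytotoxicity, read by MTT assay, with a stated time of 72 h; a higher number here means a weaker inhibitor, a lower number a stronger inhibitor. Compound 1 `N/C(=N\NC(=S)N1CCOCC1)c1ccccn1` gives 680 nM. Compound 2 `Cc1ccnc(/C(N)=N/NC(=S)N2CCOCC2)c1` gives 1600 nM. Going by the values given here, the only measured step, a 2.4-fold higher number from compound 1 to compound 2 (0.37 log units; beyond the scatter), places compound 2 at the highest of the two numbers, with compound 1 as its nearest neighbour.

Compound 3 `Cc1ccnc(/C(N)=N/NC(=S)N2CCCC2)c1` is not yet measured. It differs from compound 2 in one place: pyrrolidin-1-yl in place of morpholin-4-yl on a thiocarbonyl carbon. Among the compounds with values here, no measured step touches this position; the single step known, a 2.4-fold higher number from compound 1 to compound 2 (0.37 log units; beyond the scatter), concerns a methyl on an aromatic carbon and says nothing about exchanging one saturated ring for another on the thiocarbonyl carbon. There is therefore no basis in these numbers for expecting a shift in this assay in either direction, and the expectation is that compound 3 lands near compound 2, within the usual scatter, so that no change at the digits printed from compound 2 to compound 3 (within the scatter) is expected to be small. The estimate for compound 3 in this assay is 1600 nM, with a range from 500 nM to 5000 nM.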

Compound 3, half-maximal inhibitory concentration: 720 nM
Compound 3: the middle estimate sits 2.2-fold (0.35 log units) above what was measured; measured number inside the range.
By their numbers in this assay, from the lowest: compounds 1 and 3 (each within the scatter of the next); then compound 2.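

The ring on the thiocarbonyl carbon is not a silent position: in this assay the exchange of morpholin-4-yl for pyrrolidin-1-yl gives a 2.2-fold lower number from compound 2 to compound 3 (0.35 log units; beyond the scatter) and so counts as a real, if modest, change. Going by these compounds alone, until now the only measured change was a methyl on an aromatic carbon, and this step adds a second place where the structure affects the read-out, with the lower number, and thus the stronger inhibitor, going with the pyrrolidin-1-yl ring. Nothing at hand says why the number falls.

The exchange alters two things at once, the ring size and the presence of the ring oxygen, so the compounds shown cannot separate them; piperidin-1-yl, a six-membered ring without oxygen, would pull the two apart, while an open-chain dimethylamino group would ask whether a ring is needed at all. From the compounds shown here alone, it also remains open whether the same exchange would move the number in the same way on the core of compound 1, which lacks the methyl.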